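A few compounds are considered here, and "the series" means these few. Any claim that something is new, unique, unknown or untested is made for them only; others in the source may bear on it.

Compound 1, `CCOC(=O)c1cnn(-c2nc(-c3ccccc3Cl)c(C#N)c(=O)n2C)c1N`: 102 ug/mL
Compound 2, `CSc1nc(-c2ccco2)c(C#N)c(=O)n1C`: 90 ug/mL
Compound 3, `Cn1c(NN)nc(-c2cccs2)c(C#N)c1=O`: 68 ug/mL

Of the compounds shown here, three have been measured in a functional assay on microsomes for inhibition, with a stated time of 1 h; a higher number here means a weaker inhibitor, a lower number a stronger inhibitor. Compound 1 gives 102 ug/mL in this assay, the highest of the three numbers, while compound 2 gives 90 ug/mL and compound 3 gives 68 ug/mL. Both gaps from compound 1 lie within the scatter of repeated measurements, so the three numbers cannot be placed in an order. Compound 4, `CCOC(=O)c1cnn(-c2nc(-c3ccco3)c(C#N)c(=O)n2C)c1N`, has not yet been measured. It differs from compound 1 in one place: furan-2-yl in place of 2-chlorophenyl on an aromatic carbon. Among the compounds with values here, no pair of measured compounds differs in a single place, so no measured step can be read across to this change. Compound 2 also carries a furan-2-yl group on the shared core and gives 90 ug/mL in this assay, but its core differs elsewhere, so it offers only a hint. The step is expected to stay within the scatter in either direction, a 1.1-fold lower number from compound 1 to compound 4 (0.05 log units; within the scatter). Compound 4 is therefore expected to give about 90 ug/mL in this assay, within a range from 45 ug/mL to 180 ug/mL.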

Compound 4, half-maximal inhibitory concentration: 116 ug/mL
Compound 4: the middle estimate sits 1.3-fold (0.11 log units) below what was measured; the measured number falls inside the stated range.
By their numbers in this assay, from the lowest: compounds 3, 2, 1 and 4 (each within the scatter of the next).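

In this assay, within the data shown here, the change to furan-2-yl in place of 2-chlorophenyl, on the aromatic carbon ortho to a cyano group, gives a 1.1-fold higher number from compound 1 to compound 4 (0.06 log units; within the scatter) and is the first step that differs in one place only. With the rest of compound 1 held fixed, a six-membered aromatic ring of carbon bearing chlorine and a five-membered aromatic ring with one hetero atom therefore cannot be told apart at this position. Nothing available bears on why the two groups read alike.

The compounds shown leave open whether any group at this position, such as an amine, a carboxylic acid or a longer alkyl chain, would move the number beyond the scatter. Also open, from the compounds shown here alone, is whether this step would read the same with a different group elsewhere on the shared core.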